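The compounds below may be only part of what the source reports. "The series", "measured", "known", "first", "only" and "open" are said of these compounds alone.

In a physicochemical assay for solubility (on this read-out lower numbers stand for lower solubility and higher numbers for higher solubility), three compounds sharing a core have been measured, and none has yielded a number. Compound 1 (`Nc1cccc2c(=O)[nH]c(-c3ccc(C(F)(F)F)cc3)cc12`) gives > 30000000 nM, which is a limit of the assay. Compound 2 (`COc1ccc(-c2cc3c(N)cccc3c(=O)[nH]2)cc1`) gives > 30000000 nM, also a limit. As far as these compounds go, compound 3 (`Nc1cccc2c(=O)[nH]c(-c3cccs3)cc12`) gives > 30000000 nM, likewise a limit, so its true position is unknown. The evidence so far is the limit of > 30000000 nM in this assay, at which 3 of the 3 values shown sit.

Compound 4 (`CCc1cc2c(N)cccc2c(=O)[nH]1`) carries ethyl in place of thiophen-2-yl on an aromatic carbon. Going by the values given here, only one measured step bears on this change, and it is at the same place in the structure. Methoxy in place of trifluoromethyl gave a step that the two limits leave unreadable from compound 1 to compound 2, so it offers no size to carry over. Among the compounds with values here, no measured compound has a group without a ring at this place, which leaves the expectation loose. The expected change in this assay is a number no higher from compound 3 to compound 4 (the limit leaves the size open), with no direction that the data can support, and a further limit is the likeliest report. Compound 4 is estimated at 30000000 nM, with an expected range from 12000000 nM to 60000000 nM.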

Compound 4, solubility: > 30000000 nM
Compound 4: only a limit was reported; the forecaster's own chance of this, stated with the estimate: 80%; the middle value sits exactly at the limit.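

Compound 3 and compound 4 are each reported only as a limit in this assay, so the step between them cannot be read. The compounds shown leave open where the true read-out of any of them lies, and whether the groups compared differ at all: the limit of > 30000000 nM in this assay, at which 4 of the 4 values shown sit.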